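Swapping the indolyl group for pyridin-2-yl

This account rests on a few compounds, and the source may have more. Where it says the series, first, only, none or still open, it means among the compounds named here.

Measured in a physicochemical assay for lipophilicity, at pH 7.4; a lower number here means a more polar compound, a higher number a more lipophilic compound:
- compound 1 `CNC(=O)c1cc(C(=O)NC2CC2)cc2c1OC[C@H]2c1cccc2[nH]ccc12`: 3.5
- compound 2 `CNC(=O)c1cc(C(=O)N[C@H]2[C@@H]3COC[C@@H]32)cc2c1OC[C@H]2c1cccc2[nH]ccc12`: 3.1
- compound 3 `CNC(=O)c1cc(C(N)=O)cc2c1OC[C@H]2c1ccccc1`: 2.7

In this assay, compound 2 stands at 3.1, the middle of the three numbers, with compound 1 higher and compound 3 lower. The next compound, compound 4 `CNC(=O)c1cc(C(=O)N[C@H]2[C@@H]3COC[C@@H]32)cc2c1OC[C@H]2c1ccccn1`, has not yet been measured. It differs from compound 2 by one change, pyridin-2-yl in place of 1H-indol-4-yl on a saturated ring carbon.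

Among the measured compounds shown here, no measured step covers this place. The only one, a number 0.40 log units lower from compound 1 to compound 2 (beyond the scatter), is a change on an amide-type nitrogen, so it offers only a rough sense of scale. Compound 3, which also lacks the 1H-indol-4-yl, gives 2.7, but it differs from compound 2 elsewhere too. That value nevertheless points downward, and the smaller group entering adds to this expectation. The expected step is a number 0.90 log units lower from compound 2 to compound 4 (beyond the scatter), a fall beyond the scatter and larger than the one measured. The estimated value for compound 4 is 2.2, with an expected range from 1.8 to 2.6.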

Compound 4, distribution coefficient: 1.6
Beside the measured number, compound 4's estimate is 0.60 log units above it; measured number outside the range, below it.
By their numbers in this assay, from the lowest: compound 4; then compound 3; then compound 2; then compound 1.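

In this assay, the change on the saturated ring carbon gives a number 1.50 log units lower from compound 2 to compound 4 (beyond the scatter), a larger step than a number 0.40 log units lower from compound 1 to compound 2 (beyond the scatter) on the amide-type nitrogen. Among the compounds shown here, this is the first measured step at this position, and it shows that the place can move the number further than the one change measured before it. The step combines several differences, as 1H-indol-4-yl gives way to pyridin-2-yl, which has fewer heavy atoms, and a hydrogen-bond donor gives way to a hydrogen-bond acceptor, and nothing shown explains its size.

The compounds shown do not separate these differences, and they do not show whether pyridin-3-yl, with its ring nitrogen placed elsewhere, would give a similar step. Nor do they show whether the step would be the same with the cyclopropyl group of compound 1 on the amide-type nitrogen.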